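A few compounds are considered here, and "the series" means these few. Any claim that something is new, unique, unknown or untested is made for them only; others in the source may bear on it.

The three compounds measured so far in a functional assay for agonist activity at P2Y purinoceptor 2 (Homo sapiens), read by FLIPR (on this read-out higher numbers stand for an effect only at larger amounts of compound and lower numbers for an effect already at smaller amounts), are:

Compound 1, `COc1cccc2sc([C@@H]3O[C@H](COP(=O)(O)OP(=O)(O)OP(=O)(O)O)[C@@H](O)[C@H]3O)nc12`, which gives 700 nM.
Compound 2, `O=P(O)(O)OP(=O)(O)OP(=O)(O)OC[C@H]1O[C@@H](c2nc3ccc(Cl)cc3s2)[C@H](O)[C@@H]1O`, which gives 8 nM.
Compound 3, `O=P(O)(O)OP(=O)(O)OP(=O)(O)OC[C@H]1O[C@@H](c2nc3cc(C(F)(F)F)ccc3s2)[C@H](O)[C@@H]1O`, which gives 10 nM.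

Compound 3 stands second highest of these three numbers. Its nearest neighbour is compound 2, whose number is lower by an amount that lies within the usual scatter, so the two cannot be told apart on these data. Its furthest neighbour is compound 1, whose number is higher by a margin well beyond the scatter.

The next compound, compound 4, `O=P(O)(O)OP(=O)(O)OP(=O)(O)OC[C@H]1O[C@@H](c2nc3ccccc3s2)[C@H](O)[C@@H]1O`, differs from compound 3 in one place: hydrogen in place of trifluoromethyl on an aromatic carbon. Among the measured compounds shown here, no directly comparable pair among the measured compounds shows what this change does, so the expectation rests on the spread of the three values alone. Compounds 2 and 3, each carrying a single substituent on the six-membered ring of the core, sit close together, while compound 1 sits far higher. Removing the trifluoromethyl is expected to shift the number modestly upward, by a 2.5-fold higher number from compound 3 to compound 4 (0.40 log units; beyond the scatter), though a result within the scatter of compound 3 would not be surprising. Compound 4 is therefore estimated at 25 nM, with a range from 8 nM to 80 nM.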

Compound 4, half-maximal effective concentration: 22 nM
Compound 4: the middle estimate sits 1.1-fold (0.06 log units) above what was measured, within the range that was stated.
By their numbers in this assay, from the lowest: compounds 2 and 3 (each within the scatter of the next); then compound 4; then compound 1.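

Compound 4 carries only hydrogen on the six-membered aromatic ring, so it gives the first reference point for the shared core in this assay, and the trifluoromethyl group can now be read as a real but modest gain on this read-out: a 2.2-fold higher number from compound 3 to compound 4 (0.34 log units; beyond the scatter) is beyond the scatter. The chloro group of compound 2 reads the same way, with a 2.8-fold higher number from compound 2 to compound 4 (0.44 log units; beyond the scatter), so neither substituent is needed for a low number, and each lowers it only modestly from where the bare core already stands. The methoxy group of compound 1 goes against this pattern, since a 32-fold lower number from compound 1 to compound 4 (1.50 log units; beyond the scatter) shows that taking it away lowers the number by a large step, so a substituent on this ring can cost far more than the other two gain, and no measurement to hand explains either direction.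

The compounds shown do not separate the effect of each group from that of the ring carbon carrying it, so it stays open how methoxy would behave on the carbon that holds the trifluoromethyl in compound 3. On these data alone, it also stays open whether an amine, a carboxylic acid or a simple methyl on that carbon would follow the modest gain or the large loss.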